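Notes on compound 1 and its des-cyano analogue compound 4

A few compounds are considered here, and "the series" means these few. Any claim that something is new, unique, unknown or untested is made for them only; others in the source may bear on it.

Measured so far in an assay on cells for inhibition of Amine oxidase [flavin-containing] A (Homo sapiens), read by fluorescence and spectrophotometry, using microsomes, with a stated time of 20 min; on this read-out lower numbers stand for stronger inhibition and higher numbers for weaker inhibition:
- compound 1 `N#Cc1ccc(-c2nnc(-c3ccc(S(N)(=O)=O)cc3)o2)cc1`: 24300 nM
- compound 2 `Cc1ccc(-c2nnc(-c3cccc(S(N)(=O)=O)c3)o2)cc1`: 61400 nM
- compound 3 `NS(=O)(=O)c1cccc(-c2nnc(-c3ccc(Cl)cc3)o2)c1`: > 100000 nM, a limit of the assay, as the limit of > 100000 nM in this assay, at which 1 of the 3 values shown sits, shows.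

Compound 1 has the lowest number of the two numbers given; compound 2 stands nearest, beyond the scatter. Compound 4 `NS(=O)(=O)c1ccc(-c2nnc(-c3ccccc3)o2)cc1` differs from compound 1 by hydrogen in place of cyano on an aromatic carbon. Within the data shown here, the only measured step, an at least 1.6-fold higher number from compound 2 to compound 3 (0.21 log units; that floor lies within the scatter), concerns a different change on a different ring and so does not bear directly on it; no measured pair shows loss of a cyano group. Compound 4 is therefore expected close to compound 1, with a modest shift toward a higher number allowed, a 1.6-fold higher number from compound 1 to compound 4 (0.22 log units; within the scatter). The estimate for compound 4 in this assay is 40000 nM, within 12000 nM to 150000 nM.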

Compound 4, half-maximal inhibitory concentration: 63900 nM
Beside the measured number, compound 4's estimate is 1.6-fold (0.20 log units) below it, and the stated range covers the measured number.
By their numbers in this assay, from the lowest: compound 1; then compounds 2 and 4 (each within the scatter of the next). At a limit, above all of these: compound 3.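

In this assay, the aromatic carbon para to a large group responds to substitution: a 2.6-fold higher number from compound 1 to compound 4 (0.42 log units; beyond the scatter) for hydrogen in place of cyano. Among these compounds, this is the first single change to give a step beyond the scatter, so the shared core alone does not set the number for compound 1. Nothing at hand gives a cause for this step.

Going by these compounds, whether the step is particular to cyano stays open; an amine or a carboxylic acid on this carbon would test that. On these data alone, whether the same change carries over to the core of compound 2 also stays open.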